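A few compounds are considered here, and "the series" means these few. Any claim that something is new, unique, unknown or untested is made for them only; others in the source may bear on it.

Measured in an assay on isolated protein for inhibition of DNA topoisomerase 1 (Homo sapiens), tested at 100 uM; a lower number here means a weaker effect, a higher number a stronger effect of the compound at the concentration tested:
compound 1 `Clc1ccc(-c2cc(-c3ccsc3)nc(-c3ccco3)c2)o1` gives 8.2%
compound 2 `Clc1ccc(-c2cc(-c3ccsc3)nc(-c3ccccc3Cl)c2)o1` gives 0%
compound 3 `Cc1cccc(-c2cc(-c3ccc(Cl)o3)cc(-c3ccsc3)n2)c1` gives 7.5%

All three numbers are low and of a piece: compound 3 is nearest to compound 1 and furthest from compound 2, yet both gaps, a number 0.7 percentage points lower from compound 1 to compound 3 (within the scatter) and a number 7.5 percentage points higher from compound 2 to compound 3 (within the scatter), lie within the scatter, as does a number 8.2 percentage points lower from compound 1 to compound 2 (within the scatter).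

Compound 4 `Cc1ccccc1-c1cc(-c2ccc(Cl)o2)cc(-c2ccsc2)n1` differs from compound 3 only at the ring carbon next to the ring nitrogen: 2-methylphenyl in place of 3-methylphenyl on an aromatic carbon. The measured steps bearing on this change are the three exchanges at that same position, each within the scatter. No step beyond the scatter is therefore expected in this assay; the expected step is a number 1.5 percentage points lower from compound 3 to compound 4 (within the scatter). Compound 4 is estimated at 6%, range 0% to 16%.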

Compound 4, a percentage reported as inhibition, at one concentration (the size of the read-out at that concentration, not a potency): 6.7%
Beside the measured number, compound 4's estimate is 0.7 percentage points below it; the range from low to high includes it.
By their numbers in this assay, from the lowest: compounds 2, 4, 3 and 1 (each within the scatter of the next).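

Shifting the methyl from 3-methylphenyl to 2-methylphenyl, next to the ring nitrogen, gives a number 0.8 percentage points lower from compound 3 to compound 4 (within the scatter) in this assay, so this change of attachment on the phenyl ring leaves no readable difference. The comparison with chloro gives a number 6.7 percentage points higher from compound 2 to compound 4 (within the scatter) and the exchange with furan-2-yl gives a number 1.5 percentage points lower from compound 1 to compound 4 (within the scatter), so all four groups at this position remain indistinguishable. No independent data accompany these read-outs.

On these data alone, whether an amine or a carboxylic acid at this position would leave this narrow band stays open. Also open is what replacing the 5-chlorofuran-2-yl or thiophen-3-yl group would do, since both are common to all the compounds shown.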